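A few compounds are considered here, and "the series" means these few. Any claim that something is new, unique, unknown or untested is made for them only; others in the source may bear on it.

Measured so far in a functional assay on Jurkat cells (Homo sapiens) for inhibition; on this read-out higher numbers stand for weaker inhibition and lower numbers for stronger inhibition:
Compound 1 `CC(C)c1cc(OCC(=O)[C@H](CC(=O)O)NC(=O)[C@@H](NC(=O)COc2cccc3ccccc23)C(C)C)no1`: compound 1 gives > 200000 nM, a limit of the assay and not a number.
Compound 2 `CC(C)[C@H](NC(=O)COc1cccc2ccccc12)C(=O)N[C@@H](CC(=O)O)C(=O)CSc1nncn1C`: compound 2 gives > 200000 nM, again a limit of the assay.
Compound 3 `CC(C)[C@H](NC(=O)COc1cccc2ccccc12)C(=O)N[C@@H](CC(=O)O)C(=O)COc1ccc2ccccc2n1`: compound 3 gives > 200000 nM, also a limit of the assay.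

Compound 3 thus stands at the same limit as the other two, all three values sitting at the limit of > 200000 nM in this assay, at which 3 of the 3 values shown sit. The steps a step that the two limits leave unreadable from compound 1 to compound 2, a step that the two limits leave unreadable from compound 1 to compound 3 and a step that the two limits leave unreadable from compound 2 to compound 3 are unreadable in size and direction. Compound 4 `CC(C)[C@H](NC(=O)COc1cccc2ccccc12)C(=O)N[C@@H](CC(=O)O)C(=O)COc1cccc2cccnc12` differs from compound 3 by quinolin-8-yl in place of quinolin-2-yl on an oxygen on a saturated carbon. Among the measured compounds shown here, no measured step bears on this change, and none of the measured steps is readable, so the expectation for compound 4 in this assay is no step beyond the scatter, a number no higher from compound 3 to compound 4 (the limit leaves the size open), most likely again only a limit. Compound 4 is estimated at 200000 nM, range 100000 nM to 400000 nM.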

Compound 4, half-maximal inhibitory concentration: > 200000 nM
Compound 4 gave a limit, no number; the forecaster's own chance of this, stated with the estimate: 85%; the middle value sits exactly at the limit.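

Among the compounds shown here, no step among compound 1, compound 2, compound 3 and compound 4 can be read, since each value is only a limit: the limit of > 200000 nM in this assay, at which 4 of the 4 values shown sit. The compounds shown leave open whether any group at this place gives a number rather than a limit.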